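Aminocyclobutyl ether to methylpiperidinyl ether on the shared core

This account rests on a few compounds, and the source may have more. Where it says the series, first, only, none or still open, it means among the compounds named here.

Compound 1 `Cc1cc(Cl)cc(-c2ccnc3cc(CN4C(=O)CCC4=O)sc23)c1O[C@H]1C[C@H](N)C1`: 150 nM
Compound 2 `Cc1cc(Cl)cc(-c2ccnc3cc(CN4C(=O)C5C(C4=O)C5(C)C)sc23)c1CC1CCCNC1`: 130 nM

Both measured compounds were tested in an assay on RKO cells for inhibition of ubiquitin carboxyl-terminal hydrolase 7 (Homo sapiens), read by a luciferase reporter, with a stated time of 18 h; on this read-out higher numbers stand for an effect only at larger amounts of compound and lower numbers for an effect already at smaller amounts. Compound 1 gives 150 nM, the higher of the two numbers, while compound 2 gives 130 nM, a gap that lies within the usual scatter. Compound 3 `Cc1cc(Cl)cc(-c2ccnc3cc(CN4C(=O)CCC4=O)sc23)c1O[C@@H]1CCNC[C@@H]1C` differs from compound 1 by 3-methylpiperidin-4-yl in place of 3-aminocyclobutyl on an oxygen on an aromatic ring. Within the data shown here, no step between two measured compounds isolates this change, so nothing in the data fixes its direction. In this assay the step from compound 1 to compound 3 is expected to be small, a 1.3-fold lower number from compound 1 to compound 3 (0.10 log units; within the scatter), not clearly beyond the scatter. Compound 3 is therefore expected near 120 nM, with a range of 40 nM to 400 nM.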

Compound 3, half-maximal effective concentration: 150 nM
Estimate against measurement, compound 3: 1.3-fold (0.10 log units) below; measured number inside the range.
By their numbers in this assay, from the lowest: compounds 2, 1 and 3 (each within the scatter of the next).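

In this assay, 3-methylpiperidin-4-yl in place of 3-aminocyclobutyl on an oxygen on an aromatic ring gives no change at the digits printed from compound 1 to compound 3 (within the scatter), so this position accepts a six-membered non-aromatic ring as readily as a four-membered one of carbon only. This is the only step shown that isolates the change at this position. No measured evidence bears on why the two groups read alike. Still open, going by these compounds, is whether plain piperidin-4-yl without the methyl reads the same as compound 3. Also open, on these data alone, is whether an open-chain group such as 2-aminoethyl, or a carboxylic acid, would be accepted on that oxygen.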